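Replacing a Chloropropyl Chain with a Vinyl Group

The source may report more compounds than this note shows. Statements on the series, on what has been measured and on what is new or still open speak of the compounds shown alone.

Measured so far:
Compound 1 `O=C(NCCCCl)Nc1ccc(I)cc1`: 90000 nM
Compound 2 `O=C(CCCCl)Nc1ccc(I)cc1`: > 100000 nM

In a functional assay on HT-29 cells (Homo sapiens) for antiproliferative activity, with a stated time of 48 h (on this read-out higher numbers stand for weaker inhibition and lower numbers for stronger inhibition), compound 1 gives 90000 nM. For compound 2 this assay reports only a limit, > 100000 nM, so compound 2 stands at the limit of > 100000 nM in this assay, at which 1 of the 2 values shown sits, rather than at a number. Among the measured compounds shown here, the only measured step, an at least 1.1-fold higher number from compound 1 to compound 2 (0.04 log units; that floor lies within the scatter), swaps 3-chloropropyl for (3-chloropropyl)amino on the carbonyl carbon and so does not touch the group changed next; no measured step bears on the step to compound 3. Compound 3 `C=CC(=O)Nc1ccc(I)cc1` carries vinyl in place of 3-chloropropyl on a carbonyl carbon. Without a guide, compound 3 is expected at 30000 nM, between 3000 nM and 100000 nM, an expected step of an at least 3.3-fold lower number from compound 2 to compound 3 (0.52 log units; beyond the scatter).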

Compound 3, half-maximal inhibitory concentration: 15000 nM
Compound 3: middle estimate off by 2.0-fold (0.30 log units), on the high side, and the stated range covers the measured number.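

Vinyl on the carbonyl carbon gives the first step in this series that clearly exceeds the scatter, with an at least 6.6-fold lower number from compound 2 to compound 3 (0.82 log units; beyond the scatter) and a 6.0-fold lower number from compound 1 to compound 3 (0.78 log units; beyond the scatter). The first of these steps is only a floor, since compound 2 has a limit rather than a number: the limit of > 100000 nM in this assay, at which 1 of the 3 values shown sits.

The compounds shown leave open whether the double bond or the smaller group accounts for the gain, since vinyl differs from 3-chloropropyl in both. An ethyl group on the same carbonyl carbon would help separate the two.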